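The source may hold more compounds than are shown below. What is called first, only, known or untested is meant among the compounds shown, and "the series" means these compounds.

Working notes on the series, read in an ADME assay on cells (Fibroblast, Homo sapiens) for antiproliferative activity, with a stated time of 48 h; on this read-out lower numbers stand for stronger inhibition and higher numbers for weaker inhibition. Compound 1 `CCN(CC)c1ccc(-c2ccc(C(=O)O)cc2)nn1` gives > 25000 nM, which is a limit of the assay and not a number. Within the data shown here, compound 2 `CCOC(=O)c1ccc(-c2ccc(N(CC)CC)nn2)cc1` gives 3000 nM, the only true number so far, so it has no numeric neighbour to be ranked against. Among the measured compounds shown here, the single measured step is an at least 8.3-fold lower number from compound 1 to compound 2 (0.92 log units; beyond the scatter), with ethyl in place of hydrogen on an oxygen next to a carbonyl group, and it lies beyond the scatter.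

Compound 3 `CCOC(=O)c1ccc(-c2ccc(OC(C)C)nn2)cc1` keeps that ethyl group and changes another place, with isopropoxy in place of diethylamino on an aromatic carbon. For the measured compounds named here, the measured step therefore gives no size for this change, and no measured pair tests it. With no direction supported, the working expectation in this assay is no step beyond the scatter, anchored on compound 2 at 3000 nM, with wide uncertainty on both sides. The expected step is a 1.3-fold higher number from compound 2 to compound 3 (0.12 log units; within the scatter). For compound 3 the estimated value is 4000 nM, with an expected range of 1200 nM to 15000 nM.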

Compound 3, half-maximal inhibitory concentration: > 25000 nM
Compound 3: no number, only a limit; the forecaster's own chance of this, stated with the estimate: 15%; middle value at least 6.2-fold (0.79 log units) away from the limit.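

Among these compounds, compound 3 is the first variation at this position, the aromatic carbon next to the ring nitrogen, and the read-out responds to it: isopropoxy in place of diethylamino gives an at least 8.3-fold higher number from compound 2 to compound 3 (0.92 log units; beyond the scatter). In this assay compound 3 gives > 25000 nM, which is a limit of the assay and not a number, so the step sets only a minimum size and the full effect of the change cannot be read. Compound 2 now differs in one place from each of the other two compounds, and each of those single changes, at the ethyl group or at the diethylamino group, leads to the same ceiling of the read-out: the limit of > 25000 nM in this assay, at which 2 of the 3 values shown sit.

On these data alone, it remains open whether the amine nitrogen itself matters at this position or whether other groups would serve as well, since a smaller amine such as dimethylamino, a cyclic amine such as morpholine, or a longer alkoxy chain would each test a different part of this change. Also open, as far as these compounds go, is whether a methyl ester or an amide in place of the ethyl ester would hold the value of compound 2 at 3000 nM.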